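An Ester in Place of the Acid on Compound 2

The compounds below may be only part of what the source reports. "The series", "measured", "known", "first", "only" and "open" are said of these compounds alone.

Compound 1, `CC#CCn1c(N2CCC[C@@H](N)C2)nc2c1c(=O)n(Cc1cc(Cl)ccc1C(=O)O)c(=O)n2C`, gives > 100000 nM in an ADME assay on isolated protein for inhibition of Dipeptidyl peptidase 9 (Homo sapiens), with stated times of 15 min, 60 s and 20 min (a lower number here means a stronger inhibitor, a higher number a weaker inhibitor), which is a limit of the assay.
Compound 2, `CC#CCn1c(N2CCC[C@@H](N)C2)nc2c1c(=O)n(Cc1cc(OC)ccc1C(=O)O)c(=O)n2C`, gives > 100000 nM in this assay, again a limit.

Going by the values given here, the only step among the measured compounds, a step that the two limits leave unreadable from compound 1 to compound 2, cannot be read because both values sit at the limit of > 100000 nM in this assay, at which 2 of the 2 values shown sit. Compound 2 therefore stands at that limit, with no number of its own. The next compound, compound 3, `CC#CCn1c(N2CCC[C@@H](N)C2)nc2c1c(=O)n(Cc1ccc(Cl)cc1C(=O)OCC)c(=O)n2C`, differs from compound 2 by 4-chloro-2-(ethoxycarbonyl)phenyl in place of 2-carboxy-5-methoxyphenyl on a saturated chain carbon bound to an aromatic nitrogen. Among the compounds with values here, no measured step bears on this change: the one step at hand gives neither size nor direction, so the numbers carry no expectation of a change beyond the scatter. Compound 3 is accordingly estimated at 100000 nM, with a range from 20000 nM to 300000 nM. The expected step of a number no higher from compound 2 to compound 3 (the limit leaves the size open) is thus estimated as none beyond the scatter, and a further limit is considered likely.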

Compound 3, half-maximal inhibitory concentration: > 100000 nM
Compound 3 was reported as a limit; the forecaster's own chance of this, stated with the estimate: 70%; the middle value lies on the limit itself.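

Compound 3 also gives only a limit, so the steps linking it to compound 1 and compound 2 cannot be read, because all three values sit at the same limit: the limit of > 100000 nM in this assay, at which 3 of the 3 values shown sit. How strongly each of these compounds inhibits the enzyme in this assay stays open, as does any difference among them.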